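The source may report more compounds than this note shows. Statements on the series, on what has been measured and on what is new or still open speak of the compounds shown alone.

Measured compounds:
- compound 1, `O=C1CCCCC1S(=O)(=O)Nc1ccc(Cl)cc1C(F)(F)F`, gives 11.2% in a functional assay on KB cells (Homo sapiens) for antiproliferative activity, read by sulforhodamine B assay, tested at 100 ug/mL; on this read-out lower numbers stand for less inhibition and higher numbers for more inhibition at the one concentration tested (going by the name of the read-out)
- compound 2, `O=C1CCCCC1S(=O)(=O)Nc1cc(C(F)(F)F)ccc1C(F)(F)F`, gives 68.6% in this assay
- compound 3, `O=C1CCCCC1S(=O)(=O)Nc1cc(C(F)(F)F)cc(C(F)(F)F)c1`, gives 76% in this assay

All three share one core, a cyclohexanone carrying a sulfonamide that links to a substituted benzene ring. Compound 3 stands at the top of the three numbers, but compound 2 is so close that the gap between them falls within the usual scatter, and the two cannot be told apart on these data. Compound 1, with a chlorine and a single trifluoromethyl on its ring, lies far below both, a gap well beyond the scatter.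

The next compound, compound 4, `O=C1CCCCC1S(=O)(=O)Nc1cccc(C(F)(F)F)c1`, differs from compound 3 in a single place: hydrogen in place of trifluoromethyl on an aromatic carbon. One of the two trifluoromethyl groups is gone, so compound 4 carries only one.

For the measured compounds named here, no measured pair here differs in exactly this way, so the size of the step is uncertain. Going by the values given here, since compound 3 gives 76% while compound 1, the only compound with a single trifluoromethyl, gives 11.2%, a drop beyond the scatter is expected for compound 4, and the step of a number 48 percentage points lower from compound 3 to compound 4 (beyond the scatter) is the expected size of that drop. Compound 4 is therefore estimated at 28%, within a range from 8% to 55%.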

Compound 4, a percentage reported as inhibition, at one concentration (the size of the read-out at that concentration, not a potency): -6.3%
Estimate against measurement, compound 4: 34.3 percentage points above; the measured number lies below the stated range.
By their numbers in this assay, from the lowest: compound 4; then compound 1; then compounds 2 and 3 (each within the scatter of the next).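

In this assay, this position turns out to matter a great deal: with hydrogen in place of trifluoromethyl on an aromatic carbon, meta to a trifluoromethyl group, the step is a number 82.3 percentage points lower from compound 3 to compound 4 (beyond the scatter) and it lies well beyond the usual scatter. The same exchange starting from the other arrangement of two trifluoromethyl groups is also large, with a number 74.9 percentage points lower from compound 2 to compound 4 (beyond the scatter), so among these three compounds the inhibition goes with carrying the second trifluoromethyl group, in either arrangement, and the one group left on compound 4 does not hold it up alone. Nothing measured here accounts for why the loss is so large.

As far as these compounds go, what remains open is whether the trifluoromethyl group itself is needed at this place, or whether another group there, such as a methyl, a methoxy, a nitrile or an amine, would keep the inhibition that hydrogen loses. These numbers also come from a single concentration, so they say how much inhibition each compound gives at that dose and leave open how potent compound 3 and compound 2 really are.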